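Hydroxyethyl for allyl on the amine of compound 2

The compounds below may be only part of what the source reports. "The series", "measured", "known", "first", "only" and "open" are said of these compounds alone.

Compound 1 `N[C@@H]1CCCc2onc(O)c21` is the parent of this small set. In a functional assay with Mus musculus as the target (on this read-out higher numbers stand for weaker inhibition and lower numbers for stronger inhibition), compound 1 gives 281000 nM. Compound 2 `C=CCNC1CCCc2onc(O)c21` carries an allyl group on the amine. For compound 2 this assay reports only a limit, > 500000 nM, so compound 2 stands at the limit among the numbers shown, and (the limit of > 500000 nM in this assay, at which 1 of the 2 values shown sits). Compound 3 `OCCNC1CCCc2onc(O)c21` differs from compound 2 by hydroxymethyl in place of vinyl on a saturated chain carbon bound to an amine nitrogen. Among the compounds with values here, no measured pair shows such a change here, so no step beyond the scatter is expected in this assay, and the expected step of an at least 1.2-fold lower number from compound 2 to compound 3 (0.09 log units; that floor lies within the scatter) is an estimate only. Compound 3 is expected at 400000 nM, with a range of 150000 nM to 1000000 nM.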

Compound 3, half-maximal inhibitory concentration: > 500000 nM
Compound 3 ended at the assay's limit; the forecaster's own chance of this, stated with the estimate: 50%; at least 1.2-fold (0.09 log units) between middle value and limit.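

Within the data shown here, compound 2 and compound 3 both stand only as limits in this assay, so no step between them can be read: the limit of > 500000 nM in this assay, at which 2 of the 3 values shown sit. The compounds shown leave open whether allyl and 2-hydroxyethyl on the amine differ at all.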